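A few compounds are considered here, and "the series" means these few. Any claim that something is new, unique, unknown or untested is made for them only; others in the source may bear on it.

Measured compounds:
Compound 1, `Cn1c(=O)c(S(=O)(=O)c2ccc(F)cc2F)cc2cnc(Nc3ccc4[nH]ncc4c3)nc21`: 30000 nM
Compound 2, `O=c1[nH]c2nc(Nc3ccc4[nH]ccc4c3)ncc2cc1S(=O)(=O)c1ccc(F)cc1F`: 15000 nM

Of the compounds shown here, two have been measured in a functional assay on DU-145 cells (Homo sapiens) for inhibition, read by trypan blue exclusion, with a stated time of 72 h; a lower number here means a stronger inhibitor, a higher number a weaker inhibitor. Compound 1 gives 30000 nM. Compound 2 gives 15000 nM. Compound 2 thus stands on the lower of the two numbers, but the gap to compound 1 lies within the scatter, so the two cannot be told apart on these data.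

The next compound, compound 3, `O=c1c(S(=O)(=O)c2ccc(F)cc2F)cc2cnc(Nc3ccc4[nH]ccc4c3)nc2n1C1CCCC1`, differs from compound 2 in one place: cyclopentyl in place of hydrogen on an aromatic nitrogen. Among the compounds with values here, no step between measured compounds covers this change, so nothing measured here speaks for its size or direction. The account expects a modest move toward a lower number in this assay, of a size that could still sit within the scatter. For compound 3 the estimate is 8000 nM, within a range of 2000 nM to 40000 nM, which means an expected step of a 1.9-fold lower number from compound 2 to compound 3 (0.27 log units; within the scatter).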

Compound 3, half-maximal inhibitory concentration: 5000 nM
Beside the measured number, compound 3's estimate is 1.6-fold (0.20 log units) above it; low and high end bracket the measured number.
By their numbers in this assay, from the lowest: compound 3; then compounds 2 and 1 (each within the scatter of the next).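

In this assay, replacing the hydrogen on this aromatic nitrogen with cyclopentyl gives a 3.0-fold lower number from compound 2 to compound 3 (0.48 log units; beyond the scatter) as a modest step beyond the scatter. Within the data shown here, this is the first step between compounds that differ in one place, and it shows that in this pair the hydrogen on this nitrogen is not needed for inhibition, since the compound carrying the five-membered carbon ring gives the lower number. No measurement at hand accounts for the size or direction of this step.

A single pair cannot show whether the lower number depends on cyclopentyl itself or would also follow from another group at this position. Cyclohexyl or a longer chain ending in an amine on the same nitrogen could show whether the number falls further, holds or rises.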